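The source may report more compounds than this note shows. Statements on the series, on what has been measured and on what is new or still open speak of the compounds shown alone.

In a physicochemical assay for metabolic stability, read by HPLC, in phosphate buffer, at pH 7.4, tested at 10 uM (a lower number here means that the compound disappears faster, a higher number that the compound lasts longer), compound 1 (`O=C(NCCCCc1ccccc1)n1c(=O)oc2ccccc21`) gives 0.75 h and compound 2 (`O=C(NCCCCc1ccccc1)n1c(=O)oc2cc(Cl)ccc21`) gives 0.967 h as its half-life. Within the data shown here, these two values lie within the scatter of each other, so compound 2 stands level with compound 1 on the only numbers at hand. Among the measured compounds shown here, compound 3 (`O=C(NCCCCc1ccccc1)n1c(=O)oc2cc(-c3ccccc3)ccc21`) carries phenyl in place of chloro on an aromatic carbon and no measured compound has a phenyl there. For the measured compounds named here, the one measured step at this place (a 1.3-fold higher number from compound 1 to compound 2 (0.11 log units; within the scatter)) is a change from hydrogen to chloro and stays small, so it guides the present change only weakly. No step beyond the scatter is therefore expected in this assay and no direction can be favoured. The expected step (a 1.1-fold lower number from compound 2 to compound 3 (0.03 log units; within the scatter)) is accordingly small. The estimate for compound 3 is 0.9 h with an expected range from 0.45 h to 1.8 h for the measurement.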

Compound 3, half-life: > 5 h
Compound 3 gave a limit, no number; the forecaster's own chance of this, stated with the estimate: 2%; middle value at least 5.5-fold (0.74 log units) away from the limit.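

In this assay compound 3 gives a limit of the assay and not a number: the limit of > 5 h in this assay, at which 1 of the 3 values shown sits.

This position, where chloro in place of hydrogen gave no step beyond the scatter, proves able to carry a change that does register: phenyl in place of chloro gives an at least 5.1-fold higher number from compound 2 to compound 3 (0.71 log units; beyond the scatter), and phenyl in place of hydrogen gives an at least 6.6-fold higher number from compound 1 to compound 3 (0.82 log units; beyond the scatter). The group placed on this aromatic carbon therefore matters, and of the two substituents shown, only phenyl produces a step beyond the scatter.

As far as these compounds go, the full size of both steps stays open, since compound 3 has only a limit. The compounds shown also do not tell whether this outcome is particular to phenyl or would also appear with a pyridine ring, a methoxy group, an amine or a carboxylic acid on the same carbon.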